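Trading Hydroxy for Fluoro on Compound 1

A few compounds are considered here, and "the series" means these few. Any claim that something is new, unique, unknown or untested is made for them only; others in the source may bear on it.

Compound 1, `Cc1nc(-c2cccc(O)c2)c(C(=O)N2CCN(c3cccc(Cl)c3)CC2)o1`: in a functional assay on HL-60 cells (Homo sapiens) for inhibition, read by MTT assay, with a stated time of 72 h (on this read-out lower numbers stand for stronger inhibition and higher numbers for weaker inhibition), compound 1 gives 105 nM.
Compound 2, `CCc1nc(-c2ccccc2F)c(C(=O)N2CCN(c3cccc(OC)c3)CC2)o1`: in this assay compound 2 gives 607 nM.

Of the two numbers measured, compound 1 stands lowest, and compound 2 lies clearly higher, beyond the usual scatter. Compound 2 differs from compound 1 in several places at once, so no single change can be read from that pair. Compound 3, `Cc1nc(-c2cccc(F)c2)c(C(=O)N2CCN(c3cccc(Cl)c3)CC2)o1`, has not been measured. It differs from compound 1 in one place only: fluoro in place of hydroxy on an aromatic carbon. Within the data shown here, no measured pair shows this change, so its effect cannot be read from the data; what is known is that the hydroxy that leaves carries a hydrogen-bond donor and acceptor that the entering fluoro lacks. Compound 3 is expected near 250 nM in this assay, plausibly between 80 nM and 800 nM. The expected step of a 2.4-fold higher number from compound 1 to compound 3 (0.38 log units; beyond the scatter) is a modest move toward weaker inhibition, possibly no larger than the scatter.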

Compound 3, half-maximal inhibitory concentration: 33.7 nM
For compound 3 the middle estimate is 7.4-fold (0.87 log units) above the measured one; measured number outside the range, below it.
By their numbers in this assay, from the lowest: compound 3; then compound 1; then compound 2.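

In this assay, fluoro in place of hydroxy on this aromatic carbon gives a 3.1-fold lower number from compound 1 to compound 3 (0.49 log units; beyond the scatter), which means stronger inhibition of the cells. The hydrogen-bond donor and acceptor counted on the hydroxy are therefore not needed here for inhibition at this level, since compound 3 lacks them and still gives the lower number. Nothing measured here explains why the number falls.

Among these compounds, only this one exchange can be read at this position, so it remains open how an amine or a carboxylic acid on the same carbon would compare with fluoro. Going by these compounds, it is also open whether fluoro would give a similar step if other parts of the core of compound 1 were changed.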